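Methoxy for fluoro on the aryl sulfone of compound 2

The source may report more compounds than this note shows. Statements on the series, on what has been measured and on what is new or still open speak of the compounds shown alone.

In an assay on isolated protein for displacement of a labelled ligand from metabotropic glutamate receptor 5 (Homo sapiens), with a stated time of 60 min, tested at 1 uM (on this read-out lower numbers stand for less inhibition and higher numbers for more inhibition at the one concentration tested (going by the name of the read-out)), the measured compounds read:
compound 1 `COc1ccc2ncc(S(=O)(=O)c3ccc(C)c(F)c3)c(N3CCC(C)CC3)c2c1`, 73%
compound 2 `CC1CCN(c2c(S(=O)(=O)c3ccc(F)cc3)cnc3cc(Cl)ccc23)CC1`, 91%
compound 3 `Cc1ccc(S(=O)(=O)c2cnc3ccc(F)cc3c2N2CCC(C)CC2)cc1Cl`, 91%

Compound 2 stands level with compound 3 at the digits shown, the gap within the scatter, and the two share the highest numbers of the three; compound 1 lies lower than compound 2 by a gap beyond the scatter.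

Compound 4 `COc1ccc(S(=O)(=O)c2cnc3cc(Cl)ccc3c2N2CCC(C)CC2)cc1` has not been measured. It differs from compound 2 in one place: methoxy in place of fluoro on an aromatic carbon. Going by the values given here, no pair of measured compounds isolates this change, so nothing fixes the size of the step. In this assay the step is expected to be small, a modest loss at most or none beyond the scatter: a number 9 percentage points lower from compound 2 to compound 4 (within the scatter) is the expected step. Compound 4 is estimated at 82%, with a range from 62% to 95%.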

Compound 4, a percentage reported as inhibition, at one concentration (the size of the read-out at that concentration, not a potency): 79%
For compound 4 the middle estimate is 3 percentage points above the measured one; low and high end bracket the measured number.
By their numbers in this assay, from the lowest: compounds 1 and 4 (each within the scatter of the next); then compounds 2 and 3 (each within the scatter of the next).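

In this assay, going by these compounds alone, the change from 4-fluorophenyl to 4-methoxyphenyl gives a number 12 percentage points lower from compound 2 to compound 4 (beyond the scatter) and is the first step that isolates a single change. This position on the aryl sulfone therefore accepts methoxy at a modest cost, with compound 4 keeping much of the inhibition of compound 2 at the one concentration tested. From the compounds shown here alone, whether an amine, a carboxylic acid or a longer chain such as butoxy would be accepted at this place remains open. No data shown here account for the size of this step.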